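The source may hold more compounds than are shown below. What is called first, only, known or untested is meant among the compounds shown, and "the series" means these compounds.

Series notes, oxime ethers on the shared core. Compound 1 `C#CCO/N=C/c1c(-c2ccc(C)cc2)nc2ccc(Br)cn12` gives 40 mg/kg in a functional assay on the whole organism (strain NMRI) with Mus musculus as the target, with a stated time of 4 h; a higher number here means that more compound is needed for the effect, a lower number that less compound is needed. Compound 2 `Cc1ccc(-c2nc3ccc(Br)cn3c2/C=N/O)cc1` gives 20 mg/kg in this assay; the step of a 2.0-fold lower number from compound 1 to compound 2 (0.30 log units; within the scatter) lies within the scatter. Compound 3 `Cc1ccc(-c2nc3ccc(Br)cn3c2/C=N/OCc2cn(Cc3ccc([N+](=O)[O-])cc3)nn2)cc1` gives 20 mg/kg in this assay, matching compound 2 at the digits given and sitting within the scatter of compound 1. Compound 4 `Cc1ccc(-c2nc3ccc(Br)cn3c2/C=N/OCc2cn(Cc3ccc(C#N)cc3)nn2)cc1` differs from compound 3 in one place: cyano in place of nitro on an aromatic carbon. Within the data shown here, no measured step touches this part of the molecule; the only measured step, at the oxygen substituent, lay within the scatter. For compound 4, therefore, no step beyond the scatter is expected: no change at the digits printed from compound 3 to compound 4 (within the scatter). The estimate for compound 4 is 20 mg/kg, with a range from 10 mg/kg to 40 mg/kg.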

Compound 4, minimum effective dose: 40 mg/kg
For compound 4 the middle estimate is 2.0-fold (0.30 log units) below the measured one; the range from low to high includes it.
By their numbers in this assay, from the lowest: compounds 2, 3, 1 and 4 (each within the scatter of the next).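

Cyano in place of nitro on an aromatic carbon, the first change read at this end of the molecule, gives a 2.0-fold higher number from compound 3 to compound 4 (0.30 log units; within the scatter) in this assay at this position. The nitro group is therefore not needed for a minimum effective dose within the scatter of compound 3, and the two groups cannot be told apart here. Nothing available bears on the reason for this result. Open, on these data alone, is whether an amine or a carboxylic acid on this carbon would give a step beyond the scatter. Also open, as far as these compounds go, is whether a longer chain in place of the 4-cyanobenzyl group would do so.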